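The compounds below may be only part of what the source reports. "The series", "measured", "known", "first", "only" and "open" are said of these compounds alone.

In a functional assay on HEK293 cells for antagonist activity at transient receptor potential cation channel subfamily V member 1 (Homo sapiens), read by FLIPR (a lower number here means a stronger inhibitor, a higher number a weaker inhibitor), compound 1 `C[C@@H]1CN(c2ncccc2Cl)CCN1c1nc2ccc(C(C)(C)C)cc2[nH]1` gives 90.4 nM. Compound 2 `Cc1cc2nc(N3CCN(c4ncccc4Cl)C[C@H]3C)[nH]c2cc1C` gives 113 nM in this assay, and it stands alongside compound 1, the gap between the two numbers lying within the scatter, so no order between them can be read. Compound 3 `Cc1cc2nc(N3CCN(c4ncccc4Cl)C[C@@H]3C)[nH]c2cc1C` differs from compound 2 as follows: the two compounds have the same atoms and bonds and differ only in configuration as drawn: 1 of 1 stereo elements differ; a stereocentre at a saturated ring carbon is drawn R in compound 2 and S in compound 3. Going by the values given here, no measured pair shows what this change in configuration does in this assay, so the direction is open. A weakening beyond the scatter is taken as the more likely outcome, expected as a 2.7-fold higher number from compound 2 to compound 3 (0.42 log units; beyond the scatter). Compound 3 is accordingly estimated at 300 nM, between 60 nM and 2000 nM.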

Compound 3, half-maximal inhibitory concentration: 5770 nM
Compound 3: the middle estimate sits 19-fold (1.28 log units) below what was measured; the whole stated range lies below it.
By their numbers in this assay, from the lowest: compounds 1 and 2 (each within the scatter of the next); then compound 3.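

The stereocentre at this saturated ring carbon turns out to be a sensitive point in the series: in this assay, redrawing it from R to S gives a 51-fold higher number from compound 2 to compound 3 (1.71 log units; beyond the scatter). The whole step belongs to configuration, on one fact: the fact that compounds 2 and 3 differ only in the configuration as drawn

The compounds shown leave open whether the same inversion on compound 1 would bring a step of similar size. Also open, from the compounds shown here alone, is whether an ethyl or a hydroxymethyl group on this ring carbon would keep the level of compound 2 in this assay.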